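The source may hold more compounds than are shown below. What is called first, only, known or untested is meant among the compounds shown, and "the series" means these compounds.

Measured in a functional assay on MT4 cells (Homo sapiens) for cytotoxicity; on this read-out lower numbers stand for higher toxicity in this test and higher numbers for lower toxicity in this test:
- compound 1 `CNC1=C(C)S(=O)(=O)O[C@@]12[C@@H](CO[Si](C)(C)C(C)(C)C)O[C@@H](n1cc(C)c(=O)n(C)c1=O)[C@@H]2O[Si](C)(C)C(C)(C)C`: > 250000 nM
- compound 2 `CC1=C(N)[C@@]2(OS1(=O)=O)[C@@H](CO[Si](C)(C)C(C)(C)C)O[C@@H](n1cc(C)c(=O)n(C)c1=O)[C@@H]2O[Si](C)(C)C(C)(C)C`: > 250000 nM

Compound 1 gives > 250000 nM, and this is a limit, not a number. Compound 2 gives > 250000 nM, which is likewise a limit. Compound 2 thus stands with compound 1 at the limit of > 250000 nM in this assay, at which 2 of the 2 values shown sit.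

Compound 3 `Cc1cn([C@@H]2O[C@H](CO[Si](C)(C)C(C)(C)C)[C@@]3(OS(=O)(=O)C(I)=C3N)[C@H]2O[Si](C)(C)C(C)(C)C)c(=O)n(C)c1=O` carries iodo in place of methyl on a double-bonded ring carbon. Among the compounds with values here, the only measured step, a step that the two limits leave unreadable from compound 1 to compound 2, is a change on an amine nitrogen and gives no size to carry over. Within the data shown here, no measured step covers this exchange. In this assay, a reading at the same limit is therefore the most likely outcome, and any readable number should lie on the side of higher toxicity. The expected step is an at least 1.3-fold lower number from compound 2 to compound 3 (0.14 log units; that floor lies within the scatter). For compound 3 the estimated value, should a number be reported, is 180000 nM, with an expected range from 60000 nM to 250000 nM.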

Compound 3, half-maximal cytotoxic concentration: 3900 nM
Compound 3: the middle estimate sits 46-fold (1.66 log units) above what was measured; measured number outside the range, below it.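

In this assay, iodo in place of methyl on the double-bonded ring carbon next to the ring sulfur gives an at least 64-fold lower number from compound 2 to compound 3 (1.80 log units; beyond the scatter), so this position responds strongly to this exchange. Compound 3 is the only compound shown with a number rather than a limit, and the other two values are limits: the limit of > 250000 nM in this assay, at which 2 of the 3 values shown sit. The step on the amine nitrogen from compound 1 to compound 2 cannot be read, which leaves this ring carbon as the only place in the series where a change can be sized.

Whether the lower number is specific to iodo remains open, as the compounds shown include neither bromo, chloro nor a plain hydrogen on this carbon. Also open, from the compounds shown here alone, is how iodo on this carbon reads with a methyl on the amine nitrogen, as in compound 1.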